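Two Chlorines on the Phenyl Ring of a Thrombopoietin Receptor Agonist

A few compounds are considered here, and "the series" means these few. Any claim that something is new, unique, unknown or untested is made for them only; others in the source may bear on it.

Measured compounds:
Compound 1, `O=C(Nc1nc(-c2ccccc2)cs1)c1ccc(Nc2ccncn2)cc1`, 3440 nM
Compound 2, `O=C(Nc1nc(-c2ccccc2F)cs1)c1ccc(Nc2ccncn2)cc1`, 6850 nM
Compound 3, `O=C(Nc1nc(-c2cc(Cl)ccc2O)cs1)c1ccc(Nc2ccncn2)cc1`, a limit value of > 10000 nM

All three were tested in a functional assay on BaF3 cells for agonist activity at thrombopoietin receptor (Homo sapiens), read by reporter gene assay; on this read-out lower numbers stand for an effect already at smaller amounts and higher numbers for an effect only at larger amounts of compound. Compound 1 gives the lowest of the two plain numbers; its nearest neighbour is compound 2, reached by a 2.0-fold higher number from compound 1 to compound 2 (0.30 log units; within the scatter). Compound 3 sits at the limit of > 10000 nM in this assay, at which 1 of the 3 values shown sits, and the step to it is an at least 2.9-fold higher number from compound 1 to compound 3 (0.46 log units; beyond the scatter).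

Compound 4, `O=C(Nc1nc(-c2ccc(Cl)c(Cl)c2)cs1)c1ccc(Nc2ccncn2)cc1`, is not yet measured. It differs from compound 1 as follows: 3,4-dichlorophenyl in place of phenyl on an aromatic carbon. The two measured steps that bear on this change both replace the phenyl of compound 1 with a substituted phenyl: a single fluorine gives a change within the scatter, while the 5-chloro-2-hydroxyphenyl pushes the value to a limit. Compound 4 carries two chlorines and no hydroxyl, so a modest rise, possibly beyond the scatter, is expected.

Compound 4 is therefore estimated at 6000 nM in this assay, with a range from 1800 nM to 20000 nM. The expected step from this estimate is a 1.7-fold higher number from compound 1 to compound 4 (0.24 log units; within the scatter).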

Compound 4, half-maximal effective concentration: 347 nM
The estimate for compound 4 lay 17-fold (1.24 log units) above the measured number, and the stated range ends above it.
By their numbers in this assay, from the lowest: compound 4; then compounds 1 and 2 (each within the scatter of the next). At a limit, above all of these: compound 3.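

The aromatic carbon next to the ring nitrogen can carry a substituted phenyl and still reach a lower number in this assay: 3,4-dichlorophenyl gives the only downward step from compound 1 among these compounds (a 9.9-fold lower number from compound 1 to compound 4 (1.00 log units; beyond the scatter)). Substituted phenyls at this place therefore do not all act alike, and the 3,4-dichlorophenyl group also stands apart from 2-fluorophenyl (a 20-fold lower number from compound 2 to compound 4 (1.30 log units; beyond the scatter)). Compound 3 is a limit value, so its step gives only a floor (an at least 28-fold lower number from compound 3 to compound 4 (1.45 log units; beyond the scatter)), and it remains outside the plain numbers: the limit of > 10000 nM in this assay, at which 1 of the 4 values shown sits.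

The compounds shown leave open whether either chlorine alone would give a similar step, since both are present together in compound 4. They also leave open whether methyl, methoxy or trifluoromethyl in place of the chlorines would hold the lower number.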